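A few compounds are considered here, and "the series" means these few. Any claim that something is new, unique, unknown or untested is made for them only; others in the source may bear on it.

Compound 1 `Nc1scc(-c2cccc(Cl)c2)c1C(=O)c1ccccc1` gives 45% in a functional assay on CHO cells for agonist activity at adenosine receptor A1 (Homo sapiens), read by fluorescence and ERK phosphorylation, with stated times of 30 min and 1.5 h, tested at 3 uM; a lower number here means a weaker effect, a higher number a stronger effect of the compound at the concentration tested.
Compound 2 `Nc1scc(-c2cccc(Cl)c2)c1C(=O)c1ccc(Cl)cc1` gives 58% in this assay.

Compound 2 stands highest of the two numbers; the step from compound 1 to compound 2 was a number 13 percentage points higher from compound 1 to compound 2 (beyond the scatter). Compound 3 `COc1cccc(-c2csc(N)c2C(=O)c2ccc(Cl)cc2)c1` differs from compound 2 by methoxy in place of chloro on an aromatic carbon. Going by the values given here, the one measured step, a number 13 percentage points higher from compound 1 to compound 2 (beyond the scatter), concerns chloro in place of hydrogen and not methoxy in place of chloro, so no step bears directly on this change. A small step, likely within the scatter, is therefore expected for compound 3, a number 8 percentage points lower from compound 2 to compound 3 (within the scatter), in this assay. The estimate for compound 3 is 50%, with a range of 30% to 70%.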

Compound 3, a percentage reported as activity, at one concentration (the size of the read-out at that concentration, not a potency): 58%
Estimate against measurement, compound 3: 8 percentage points below; measured number inside the range.
By their numbers in this assay, from the lowest: compound 1; then compounds 2 and 3 (each within the scatter of the next).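

In this assay, replacing chloro with methoxy on this aromatic carbon, meta to a large group, gives no change at the digits printed from compound 2 to compound 3 (within the scatter). Going by these compounds alone, the earlier compounds all carried chloro here, so this is the first sign that the place accepts a different group, including one with a hydrogen-bond acceptor, without a change in the read-out beyond the scatter. No available evidence explains this result. As far as these compounds go, whether an amine, a carboxylic acid or a longer chain such as ethoxy would be accepted here remains open. From the compounds shown here alone, with a read-out at one concentration, any difference in potency between compound 2 and compound 3 also remains open.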